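Methyl to chloro: compound 3 to compound 4

The compounds below may be only part of what the source reports. "The series", "measured", "known", "first", "only" and "open" are said of these compounds alone.

In a functional assay on CCRF-CEM cells (Homo sapiens) for inhibition, read by cell counting, with a stated time of 72 h (on this read-out higher numbers stand for weaker inhibition and lower numbers for stronger inhibition), compound 3 `CCN(CC)CN1C(=O)/C(=N/NC(=S)Nc2ccc(C)cc2)c2cc(Cl)ccc21` gives the lowest of the three numbers at 4600 nM. Compound 1 `CCN(CC)CN1C(=O)/C(=N/NC(=S)Nc2ccc(Cl)cc2)c2ccccc21` gives 10000 nM, and compound 2 `CCN(CC)CN1C(=O)/C(=N/NC(N)=S)c2cc(Cl)ccc21` gives 71000 nM.

Compound 4 `CCN(CC)CN1C(=O)/C(=N/NC(=S)Nc2ccc(Cl)cc2)c2cc(Cl)ccc21` departs from compound 3 in one place, with chloro in place of methyl on an aromatic carbon, para to a large group: chloro in place of methyl on an aromatic carbon. Among the compounds with values here, the only measured single change is a 15-fold lower number from compound 2 to compound 3 (1.19 log units; beyond the scatter), a large step with 4-methylphenyl in place of hydrogen on an amide-type nitrogen. That step covers adding the aryl group and says nothing on methyl against chloro. Within the data shown here, no measured pair isolates this exchange. Compound 1 carries the 4-chlorophenyl group but also differs from compound 3 on the core, so its value gives only a loose guide. No step beyond the scatter is therefore expected in this assay, and the expected change is a 1.0-fold lower number from compound 3 to compound 4 (0.01 log units; within the scatter). Compound 4 is estimated at 4500 nM, with an expected range of 2000 nM to 10000 nM.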

Compound 4, half-maximal inhibitory concentration: > 125000 nM
Compound 4: no number, only a limit; the forecaster's own chance of this, stated with the estimate: 5%; middle value at least 27-fold (1.44 log units) from the limit.
By their numbers in this assay, from the lowest: compound 3; then compound 1; then compound 2. At a limit, above all of these: compound 4.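

The reading for compound 4 is a limit of the assay and not a number: the limit of > 125000 nM in this assay, at which 1 of the 4 values shown sits. In this assay the exchange of 4-methylphenyl for 4-chlorophenyl is far from neutral on this core, with an at least 27-fold higher number from compound 3 to compound 4 (1.43 log units; beyond the scatter) and, against the hydrogen on the amide-type nitrogen, an at least 1.7-fold higher number from compound 2 to compound 4 (0.24 log units; that floor lies within the scatter), so the gain seen in a 15-fold lower number from compound 2 to compound 3 (1.19 log units; beyond the scatter) does not carry over to the chloro analogue. The chloro on the core also counts once 4-chlorophenyl is present, with an at least 12-fold higher number from compound 1 to compound 4 (1.09 log units; beyond the scatter) as the step.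

Still open, going by these compounds, is whether the loss belongs to the 4-chlorophenyl group alone or to its pairing with the core chloro. A methoxy group or an amine at this position would show how far the number of compound 3 depends on methyl.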